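The compounds below may be only part of what the source reports. "The series", "measured", "known", "first", "only" and "open" are said of these compounds alone.

Values measured in a toxicity assay on MT4 cells (Homo sapiens) for cytotoxicity, read by MTT assay; a higher number here means that more compound is tolerated, a lower number that less compound is tolerated:

- Compound 1 `Cc1cc(Oc2cc(N)nc(Nc3ccc(C#N)cc3)n2)ccc1-c1ccc(C#N)cc1`: 34300 nM
- Compound 2 `Cc1cc(-c2ccc(F)cc2)cc(C)c1Oc1cc(N)nc(Nc2ccc(C#N)cc2)n1`: 23100 nM

In this assay, compound 2 stands at 23100 nM, which lies within the scatter of compound 1 at 34300 nM. The two measured compounds therefore cannot be told apart on these numbers.

The next compound, compound 3 `Cc1ccccc1-c1cc(C)c(Oc2cc(N)nc(Nc3ccc(C#N)cc3)n2)c(C)c1`, remains to be measured. It carries 2-methylphenyl in place of the 4-fluorophenyl of compound 2 on an aromatic carbon (2-methylphenyl in place of 4-fluorophenyl on an aromatic carbon). This carbon is meta to two methyl groups and para to a large group.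

Among the measured compounds shown here, no measured pair of compounds differs in one place alone, so the data offer no direct guide to this exchange. For the measured compounds named here, the only evidence is the close agreement of compound 1 at 34300 nM and compound 2 at 23100 nM. On that basis, no change beyond the scatter is expected in this assay, and no direction is favoured. The estimated step is a 1.1-fold higher number from compound 2 to compound 3 (0.03 log units; within the scatter). For compound 3 the expected value is 25000 nM, with an estimated range from 10000 nM to 60000 nM.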

Compound 3, half-maximal cytotoxic concentration: 25600 nM
The estimate for compound 3 lay 1.0-fold (0.01 log units) below the measured number, and the stated range covers the measured number.
By their numbers in this assay, from the lowest: compounds 2, 3 and 1 (each within the scatter of the next).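

In this assay the exchange of 4-fluorophenyl for 2-methylphenyl on this aromatic carbon, meta to two methyl groups and para to a large group, gives a 1.1-fold higher number from compound 2 to compound 3 (0.04 log units; within the scatter) and so leaves the two compounds indistinguishable. This is the only pair shown that differs in one place alone, and it gives the first direct reading at this position: a six-membered aromatic ring of carbon bearing fluorine and one bearing a methyl group, each entering with the same count of heavy atoms, cannot be told apart on these numbers. No measurement at hand accounts for this outcome.

The compounds shown leave open whether the same holds for a group on this carbon that is not a substituted phenyl ring, such as an amine, a carboxylic acid or a longer alkyl chain. They also leave open how plain phenyl or 4-methylphenyl would stand on the same carbon, so this single exchange cannot yet be read as a trend for the position.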